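A few compounds are considered here, and "the series" means these few. Any claim that something is new, unique, unknown or untested is made for them only; others in the source may bear on it.

Measured so far:
compound 1 `COc1ccc(C2CC(c3ccc(OC)c(OC)c3)=NN2C(=O)CO[N+](=O)[O-])c(OC)c1` gives 38%
compound 2 `COc1ccc(C2=NN(C(=O)CO[N+](=O)[O-])C(c3c(Cl)cccc3Cl)C2)cc1OC` gives 40%
compound 3 `COc1ccc(C2CC(c3ccc(OC)c(OC)c3)=NN2C(=O)C(C)Br)c(OC)c1` gives 58%

These three were tested in a functional assay on the whole organism (strain albino) for inhibition, with Rattus norvegicus as the target, read by paw edema, with stated times of 30 min and 1 h, at a dose of 100 mg/kg by the oral route; a lower number here means less inhibition, a higher number more inhibition at the dose given (going by the name of the read-out). Compound 4 `COc1ccc(C2=NN(C(=O)C(C)Br)C(c3c(Cl)cccc3Cl)C2)cc1OC` has not yet been measured there.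

The change that leads to compound 4 has been seen once before. From compound 1 to compound 2 it is 2,6-dichlorophenyl in place of 2,4-dimethoxyphenyl on a saturated ring carbon, and in this assay the step was a number 2 percentage points higher from compound 1 to compound 2 (within the scatter). From compound 3 to compound 4 it is 2,6-dichlorophenyl in place of 2,4-dimethoxyphenyl on a saturated ring carbon. The two cores differ by 1-bromoethyl in place of (nitrooxy)methyl on a carbonyl carbon, which in this assay gave a number 20 percentage points higher from compound 1 to compound 3 (beyond the scatter). Around the place of the change, the ring atom bears a ((nitrooxy)methyl)carbonyl group in the first pair and a (1-bromoethyl)carbonyl group in the second, so the two changes are of the same kind, not the same.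

Because the earlier step was a number 2 percentage points higher from compound 1 to compound 2 (within the scatter), the step from compound 3 to compound 4 is expected to be small, about a number 2 percentage points higher from compound 3 to compound 4 (within the scatter). Compound 4 is therefore estimated at 60%, between 45% and 75%.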

Compound 4, a percentage reported as inhibition, in the whole organism at one dose (the size of the read-out at that dose, not a potency): 51%
The estimate for compound 4 lay 9 percentage points above the measured number, and the stated range covers the measured number.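

In this assay the change to 2,6-dichlorophenyl gave a number 7 percentage points lower from compound 3 to compound 4 (within the scatter) and, set beside the earlier step, it carried over between the two cores: the same change on two cores in this assay, a number 2 percentage points higher (within the scatter) from compound 1 to compound 2 and a number 7 percentage points lower (within the scatter) from compound 3 to compound 4, 9 percentage points apart, within the scatter of two such steps. The change to 1-bromoethyl gave a number 11 percentage points higher from compound 2 to compound 4 (beyond the scatter) and it carried over as well: the same change on two cores in this assay, a number 20 percentage points higher (beyond the scatter) from compound 1 to compound 3 and a number 11 percentage points higher (beyond the scatter) from compound 2 to compound 4, 9 percentage points apart, within the scatter of two such steps. Among the compounds shown here, this shows that each change behaved alike on both cores in these four compounds, but with only two pairs at one dose it does not show that either change would carry over to other cores.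

The compounds shown leave open how an unsubstituted phenyl group would behave on the saturated ring carbon. They also leave open whether an amine or a carboxylic acid in place of the 1-bromoethyl group would follow the same pattern.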